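Moving the Methyl Around the Aryl Ring of a Thiosemicarbazone

The source may report more compounds than this note shows. Statements on the series, on what has been measured and on what is new or still open speak of the compounds shown alone.

Measured so far:
compound 1, `Cc1ccc(NC(=S)NN=C(c2ccccc2)c2ccccc2)cc1`: 38 nM
compound 2, `Cc1cccc(NC(=S)NN=C(c2ccccc2)c2ccccc2)c1`: 5.9 nM

Both compounds were tested in a functional assay on HL-60 cells (Homo sapiens) for antiproliferative activity, read by MTT assay, with a stated time of 48 h; on this read-out lower numbers stand for stronger inhibition and higher numbers for weaker inhibition. Within the data shown here, compound 2 holds the lowest of the two numbers; its only neighbour is compound 1, and the step of a 6.4-fold lower number from compound 1 to compound 2 (0.81 log units; beyond the scatter) lies beyond the scatter, so the 3-methylphenyl compound is the stronger of the pair on this read-out.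

Compound 3, `Cc1ccccc1NC(=S)NN=C(c1ccccc1)c1ccccc1`, has not yet been measured. It differs from compound 2 by 2-methylphenyl in place of 3-methylphenyl on an amide-type nitrogen. Among the measured compounds shown here, the one measured step, a 6.4-fold lower number from compound 1 to compound 2 (0.81 log units; beyond the scatter), concerns a different move of the same methyl group and shows that shifting the methyl on this ring can change the number by a modest amount. For the measured compounds named here, no step describes the move to 2-methylphenyl itself, so its direction is not known from these two compounds. Taking compound 2 as the reference, the step of a 2.0-fold higher number from compound 2 to compound 3 (0.31 log units; beyond the scatter) is expected to be small, with the wider uncertainty allowing a somewhat higher number. Compound 3 is therefore estimated at 12 nM, with a range from 3 nM to 50 nM.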

Compound 3, half-maximal inhibitory concentration: 17 nM
Estimate against measurement, compound 3: 1.4-fold (0.15 log units) below; measured number inside the range.
By their numbers in this assay, from the lowest: compound 2; then compound 3; then compound 1.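

In this assay, the move to 2-methylphenyl on the amide-type nitrogen gives a 2.9-fold higher number from compound 2 to compound 3 (0.46 log units; beyond the scatter), and the comparison with the 4-methylphenyl compound gives a 2.2-fold lower number from compound 1 to compound 3 (0.35 log units; beyond the scatter). Compound 3 therefore sits in the middle of the set: all three compounds have the same atoms, yet where the methyl stands on this ring separates each from the others by more than the scatter, with 3-methylphenyl giving the lowest number and 4-methylphenyl the highest. Nothing available here accounts for this order.

The compounds shown leave open whether a chlorine or a methoxy group, moved around the same ring, would follow the order seen with methyl, and where a plain phenyl group carrying no methyl would fall relative to these three. They also leave open whether the same order would hold in other cell lines.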